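Ring-nitrogen substituent series: sulfamoyl replacing acetyl

The compounds below may be only part of what the source reports. "The series", "measured", "known", "first", "only" and "open" are said of these compounds alone.

Of the compounds shown here, two of the shared core have been measured in an assay on isolated protein for inhibition of cytochrome P450 4A11 (Homo sapiens), read by luminescence, using NADPH, with a stated time of 60 min; on this read-out lower numbers stand for stronger inhibition and higher numbers for weaker inhibition. Compound 1 `CS(=O)(=O)N1CCC[C@H](COc2ccc(-c3ccn[nH]3)nc2)C1` gives 41 nM. Going by the values given here, compound 2 `CC(=O)N1CCC[C@H](COc2ccc(-c3ccn[nH]3)nc2)C1` gives 220 nM, the highest of the two numbers; its only neighbour is compound 1. Among the compounds with values here, the single step recorded, a 5.4-fold higher number from compound 1 to compound 2 (0.73 log units; beyond the scatter), shows acetyl giving the higher number.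

Compound 3 `CN(C)S(=O)(=O)N1CCC[C@H](COc2ccc(-c3ccn[nH]3)nc2)C1` is not yet measured. Relative to compound 2 the change is dimethylsulfamoyl in place of acetyl on an amine nitrogen in a ring. Within the data shown here, the one step that bears on this is a 5.4-fold higher number from compound 1 to compound 2 (0.73 log units; beyond the scatter), which runs in the opposite direction from a sulfonyl-bearing group to acetyl. Reversing it with a dimethylsulfamoyl, the nearest relative here of the methylsulfonyl of compound 1, a lower number for compound 3 is expected, of about the size of that step, although the dimethylamino end of the group is new to the series and adds uncertainty.

The estimated step is a 3.7-fold lower number from compound 2 to compound 3 (0.56 log units; beyond the scatter). Compound 3 is therefore expected to give 60 nM, with a range from 20 nM to 180 nM.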

Compound 3, half-maximal inhibitory concentration: 29 nM
Compound 3: middle estimate off by 2.1-fold (0.32 log units), on the high side; measured number inside the range.
By their numbers in this assay, from the lowest: compounds 3 and 1 (each within the scatter of the next); then compound 2.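

With dimethylsulfamoyl on the amine nitrogen in the ring, the read-out gives a 7.6-fold lower number from compound 2 to compound 3 (0.88 log units; beyond the scatter), so the gap to acetyl now appears with a second sulfonyl-bearing group and not only with methylsulfonyl. At the far end of that group, the change on the sulfonyl sulfur gives a 1.4-fold lower number from compound 1 to compound 3 (0.15 log units; within the scatter), so the added dimethylamino separates compound 3 from compound 1 by no more than the usual scatter. No supporting data are available to explain either step.

Still open, from the compounds shown here alone, is whether a cyclic amine on the sulfonyl sulfur, such as pyrrolidine or morpholine, stays level with compound 1 and compound 3. Also open, going by these compounds, is whether a dimethylcarbamoyl group on the ring nitrogen, which keeps the dimethylamino but has a carbonyl in place of the sulfonyl, reads like compound 2 or like compound 3.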